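Tertiary amine in place of secondary amine on the core

This account rests on a few compounds, and the source may have more. Where it says the series, first, only, none or still open, it means among the compounds named here.

Measured compounds:
compound 1 `CCC(CC)Nc1nc(C)nc2c(-c3ccc(OC)nc3C)c(C)nn12` — 3.1 nM
compound 2 `CCCCN(CCC)c1nc(C)nc2c(-c3ccc(OC)nc3C)c(C)nn12` — 2.4 nM
compound 3 `CCC(CC)Nc1nc(C)nc2c(-c3cnc(N(C)C)cc3C)c(C)nn12` — 24.8 nM

In an assay on cell membranes for displacement of a labelled ligand from corticotropin-releasing factor receptor 1 (Rattus norvegicus) (a higher number here means a weaker inhibitor, a lower number a stronger inhibitor), compound 1 gives 3.1 nM, the second highest of the three numbers. Compound 2 gives 2.4 nM, within the scatter of compound 1. Compound 3, which carries a different aryl group on the shared core, gives 24.8 nM, a higher number that lies beyond the scatter from compound 1.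

Compound 4 `CCCN(CC1CC1)c1nc(C)nc2c(-c3ccc(OC)nc3C)c(C)nn12` is not yet measured. It differs from compound 1 by one change: (cyclopropylmethyl)(propyl)amino in place of (pentan-3-yl)amino on an aromatic carbon. Going by the values given here, the one measured step that bears on this is a 1.3-fold lower number from compound 1 to compound 2 (0.11 log units; within the scatter), where the same secondary (pentan-3-yl)amino on the same aromatic carbon was likewise exchanged for a tertiary dialkylamino, butyl(propyl)amino, with no step beyond the scatter. The (cyclopropylmethyl)(propyl)amino of compound 4 is another tertiary dialkylamino of similar size, so the expectation is a step of about a 1.0-fold lower number from compound 1 to compound 4 (0.01 log units; within the scatter), that is, none beyond the scatter in this assay.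

Compound 4 is therefore expected to give about 3 nM, in the range 1.2 nM to 8 nM.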

Compound 4, half-maximal inhibitory concentration: 1.6 nM
For compound 4 the middle estimate is 1.9-fold (0.27 log units) above the measured one, within the range that was stated.
By their numbers in this assay, from the lowest: compounds 4, 2 and 1 (each within the scatter of the next); then compound 3.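

In this assay, a second tertiary dialkylamino on this aromatic carbon between two ring nitrogen atoms gives a 1.9-fold lower number from compound 1 to compound 4 (0.29 log units; within the scatter), so the exchange of (pentan-3-yl)amino, with its hydrogen-bond donor, for an amine with none again brings no step beyond the scatter. Among the tertiary amines, cyclopropyl in place of propyl on a saturated chain carbon bound to the nitrogen gives a 1.5-fold lower number from compound 2 to compound 4 (0.18 log units; within the scatter), which shows that a three-membered ring of carbon in the side chain also leaves the number within the scatter. No measurement shown explains why these steps stay so small.

On these data alone, all these steps rest on the aryl group shared by compound 1, compound 2 and compound 4, so whether they hold with the aryl group of compound 3 stays open. Also open, as far as these compounds go, is how the number responds at this position to a morpholine ring or a chain ending in a carboxylic acid.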